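This account rests on a few compounds, and the source may have more. Where it says the series, first, only, none or still open, it means among the compounds named here.

Compound 1 `CCN(CC)c1ccc2cc(C(=O)c3ccc(N4CCN(C(=O)CN5CCN(S(=O)(=O)c6ccc(OC(F)(F)F)cc6)CC5)CC4)cc3)oc2c1` gives 20100 nM in a functional assay on MCF7 cells (Homo sapiens) for cytotoxicity, read by MTT assay, with a stated time of 48 h; on this read-out higher numbers stand for weaker inhibition and lower numbers for stronger inhibition.
Compound 2 `CCN(CC)c1ccc2cc(C(=O)c3ccc(N4CCN(C(=O)CN5CCN(S(=O)(=O)c6ccc(C(F)(F)F)cc6)CC5)CC4)cc3)oc2c1` gives 17500 nM in this assay.
In this assay compound 3 `CCN(CC)c1ccc2cc(C(=O)c3ccc(N4CCN(C(=O)CN5CCN(S(=O)(=O)c6ccc(C#N)cc6)CC5)CC4)cc3)oc2c1` gives > 40000 nM, which is a limit of the assay rather than a number.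

Compound 3 therefore stands at the limit of > 40000 nM in this assay, at which 1 of the 3 values shown sits, so no exact number is known for it. Compound 4 `CCN(CC)c1ccc2cc(C(=O)c3ccc(N4CCN(C(=O)CN5CCN(Cc6ccc(C#N)cc6)CC5)CC4)cc3)oc2c1` differs from it by 4-cyanobenzyl in place of (4-cyanophenyl)sulfonyl on an amine nitrogen in a ring. Within the data shown here, none of the measured steps touches this part of the molecule: a 1.1-fold lower number from compound 1 to compound 2 (0.06 log units; within the scatter), an at least 1.9-fold higher number from compound 1 to compound 3 (0.29 log units; that floor lies within the scatter) and an at least 2.2-fold higher number from compound 2 to compound 3 (0.35 log units; beyond the scatter) each swap a substituent on the outer aromatic ring while the sulfonyl link stays in place. The measured values give no guide to the change in the link itself, and all of them sit at weak inhibition in this assay. Compound 4 is expected to stay near that region, with an expected step of a number no higher from compound 3 to compound 4 (the limit leaves the size open). Compound 4 is estimated at 40000 nM, with a range from 12000 nM to 120000 nM.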

Compound 4, half-maximal inhibitory concentration: > 40000 nM
Compound 4 was reported as a limit; the forecaster's own chance of this, stated with the estimate: 55%; the middle value sits exactly at the limit.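

Compound 3 and compound 4 are both reported only as a limit, not as a number, so no step can be read between them: the limit of > 40000 nM in this assay, at which 2 of the 4 values shown sit. As far as these compounds go, whether 4-cyanobenzyl and (4-cyanophenyl)sulfonyl differ at all in this assay stays open.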